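Three compounds at one assay limit, a fourth expected there

The compounds below may be only part of what the source reports. "The series", "measured", "known", "first", "only" and "open" are said of these compounds alone.

Compound 1 `Cc1nnc(SCc2ccccc2)n1N1C(=O)c2ccccc2C1=O` in a functional assay on HepG2 cells (Homo sapiens) for cytotoxicity, read by MTT assay, with a stated time of 48 h (on this read-out lower numbers stand for stronger inhibition and higher numbers for weaker inhibition), gives > 200000 nM, which is a limit of the assay and not a number.
Compound 2 `Cc1nnc(SCC(=O)c2ccc(Cl)cc2)n1N1C(=O)c2ccccc2C1=O` in this assay gives > 200000 nM, again a limit and not a number.
Compound 3 `CCCc1nnc(SCc2ccccc2)n1N1C(=O)c2ccccc2C1=O` in this assay gives > 200000 nM, also a limit and not a number.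

All three measured values sit at the same limit (the limit of > 200000 nM in this assay, at which 3 of the 3 values shown sit). Compound 2 differs from compound 1 by (4-chlorophenyl)carbonyl in place of phenyl on a saturated chain carbon bound to a sulfur; the step that the two limits leave unreadable from compound 1 to compound 2 has no readable size, as both of its ends are limits. The step that the two limits leave unreadable from compound 1 to compound 3 is equally unreadable.

Compound 4 `CCCc1nnc(SCC(=O)c2ccc(Cl)cc2)n1N1C(=O)c2ccccc2C1=O` has not yet been measured. Among the compounds with values here, it differs from compound 3 by (4-chlorophenyl)carbonyl in place of phenyl on a saturated chain carbon bound to a sulfur, and this is the same change as the one from compound 1 to compound 2: the place is the same, on a saturated chain carbon bound to a sulfur. The two cores differ by ethyl in place of hydrogen on a saturated chain carbon bound to an aromatic carbon.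

What can be expected for compound 4 rests on a step that the two limits leave unreadable from compound 1 to compound 2, a step that left both of its compounds at the limit, and on compound 3 standing at that limit too. For compound 4 the estimated step is a number no higher from compound 3 to compound 4 (the limit leaves the size open). Compound 4 is therefore expected at about 200000 nM, within 100000 nM to 400000 nM, and most likely the assay will again report only a limit rather than a number.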

Compound 4, half-maximal inhibitory concentration: > 200000 nM
Compound 4: only a limit was reported (the forecaster's own chance of this, stated with the estimate: 85%); the middle value sits exactly at the limit.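

In this assay compound 4 gives > 200000 nM, again a limit and not a number, so the steps to compound 4 from compound 3 and from compound 2 cannot be read, and all four compounds stand at one limit: the limit of > 200000 nM in this assay, at which 4 of the 4 values shown sit.

The compounds shown leave open whether (4-chlorophenyl)carbonyl in place of phenyl, or ethyl in place of hydrogen, changes the read-out at all.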